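The source may hold more compounds than are shown below. What is called first, only, known or untested is meant among the compounds shown, and "the series" means these compounds.

Three compounds share one core and differ in the group on an amine nitrogen, and all three were tested in a functional assay on MCF7 cells (Homo sapiens) for inhibition, read by sulforhodamine B assay; on this read-out higher numbers stand for weaker inhibition and lower numbers for stronger inhibition. Going by the values given here, compound 3 `O=C1C=C(Nc2ccc(I)cc2)C(=O)c2c1nc1n2[C@H]2OC[C@@H](O)[C@H]2OC1` gives 2230 nM, the only plain number among them. Compound 1 `O=C1C=C(NC2CCCC2)C(=O)c2c1nc1n2[C@H]2OC[C@@H](O)[C@H]2OC1` gives only a limit of the assay, > 16000 nM. Compound 2 `COc1ccccc1NC1=CC(=O)c2nc3n(c2C1=O)[C@H]1OC[C@@H](O)[C@H]1OC3` also gives only a limit, > 4000 nM.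

Compound 4 `O=C1C=C(N2CCCCC2)C(=O)c2c1nc1n2[C@H]2OC[C@@H](O)[C@H]2OC1` has not yet been measured. It carries piperidin-1-yl in place of (4-iodophenyl)amino on a double-bonded ring carbon, and the count of that change reads (piperidin-1-yl in place of (4-iodophenyl)amino on a double-bonded ring carbon). The most useful guide is an at least 7.1-fold lower number from compound 1 to compound 3 (0.85 log units; beyond the scatter), with 4-iodophenyl in place of cyclopentyl on an amine nitrogen. Compound 4 also lacks the 4-iodophenyl group and has a non-aromatic ring instead, so that step, read in reverse, points towards weaker inhibition. The step of an at least 1.7-fold lower number from compound 2 to compound 3 (0.25 log units; that floor lies within the scatter) says less, and a step that the two limits leave unreadable from compound 1 to compound 2 gives no size at all. Among the compounds with values here, no measured step shows what piperidin-1-yl itself does, so the expectation stays loose. In this assay the expected change is a 3.1-fold higher number from compound 3 to compound 4 (0.50 log units; beyond the scatter), a modest move towards weaker inhibition. Compound 4 is estimated at 7000 nM, with an expected range from 2000 nM to 25000 nM.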

Compound 4, half-maximal inhibitory concentration: > 8000 nM
Compound 4: a limit, no number (the forecaster's own chance of this, stated with the estimate: 50%); middle value at least 1.1-fold (0.05 log units) away from the limit.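

In this assay, the change at this double-bonded ring carbon gives an at least 3.5-fold higher number from compound 3 to compound 4 (0.55 log units; beyond the scatter), so losing (4-iodophenyl)amino in favour of piperidin-1-yl costs inhibition by a margin beyond the scatter. That size is only a floor, since compound 4 gives a limit of the assay and not a number: the limit of > 8000 nM in this assay, at which 1 of the 4 values shown sits. Piperidin-1-yl is also the first group here with no hydrogen-bond donor, but this one change removes the donor, the aromatic ring and the iodine together, so the step cannot say which of them matters.

The steps to compound 4 from compound 1 and from compound 2 cannot be read, as both ends of each are limits, so piperidin-1-yl cannot be ranked against cyclopentylamino or (2-methoxyphenyl)amino. As far as these compounds go, the separate parts of the change remain open: phenylamino would show what the iodine contributes, and a methyl group on the nitrogen of (4-iodophenyl)amino would show what the hydrogen on that nitrogen contributes while the iodinated ring stays in place.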